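The source may report more compounds than this note shows. Statements on the series, on what has been measured and on what is new or still open speak of the compounds shown alone.

Among the measured compounds shown here, in a functional assay on the whole organism for antagonist activity, with Mus musculus as the target (on this read-out higher numbers stand for an effect only at larger amounts of compound and lower numbers for an effect already at smaller amounts), compound 1, `CCC(=O)N(c1ccc(Cl)c(Cl)c1)C1CCCC1O`, gives 9 mg/kg, the middle of the three numbers measured so far. Compound 2, `CCC(=O)N(c1ccc(Cl)cc1)C1CCCC1N(C)C`, gives 0.2 mg/kg, the lowest number, and compound 3, `CN(C)C1CCCC1N(C=O)c1ccc(Cl)c(Cl)c1`, gives 40 mg/kg, the highest. Compound 2 and compound 3 both carry a dimethylamino group instead of hydroxy, but each also differs from compound 1 elsewhere, so neither isolates the effect of that exchange.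

Compound 4, `CCC(=O)N(c1ccc(Cl)c(Cl)c1)C1CCCC1N(C)CCN(C)C`, changes one place in compound 1: (2-(dimethylamino)ethyl)(methyl)amino replaces hydroxy on a saturated ring carbon, ((2-(dimethylamino)ethyl)(methyl)amino in place of hydroxy on a saturated ring carbon). For the measured compounds named here, no measured pair shows this exchange directly. The nearest evidence is wide, with compound 2 at 0.2 mg/kg and compound 3 at 40 mg/kg lying on either side of compound 1. In this assay, only a small move toward a lower number is therefore expected, and no step beyond the scatter can be predicted with confidence. The expected step is a 1.5-fold lower number from compound 1 to compound 4 (0.18 log units; within the scatter). For compound 4, the estimated value is 6 mg/kg, with an expected range from 1 mg/kg to 30 mg/kg.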

Compound 4, dose for half-maximal effect: 5 mg/kg
For compound 4 the middle estimate is 1.2-fold (0.08 log units) above the measured one; the measured number falls inside the stated range.
By their numbers in this assay, from the lowest: compound 2; then compounds 4 and 1 (each within the scatter of the next); then compound 3.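

In this assay, among the compounds shown here, (2-(dimethylamino)ethyl)(methyl)amino in place of hydroxy on a saturated ring carbon gives a 1.8-fold lower number from compound 1 to compound 4 (0.26 log units; within the scatter), the first reading of a single exchange at this position. On the core of compound 1, the position thus takes this much larger group, which has no hydrogen-bond donor, with no step beyond the scatter. Nothing available explains why the exchange leaves the number within the scatter.

The compounds shown leave open how dimethylamino alone would read on the core of compound 1, as compound 2 and compound 3 each differ elsewhere as well. They also leave open whether a primary amine, a methoxy group or a longer chain at this position would give a step beyond the scatter.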